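The source may report more compounds than this note shows. Statements on the series, on what has been measured and on what is new or still open speak of the compounds shown alone.

Compound 3 `Cc1nc(C(=O)O)ccc1CN1CCC[C@H](O[C@H](CO)c2cc(Cl)cc(Cl)c2)[C@@H]1c1ccccc1` gives the highest number of the three compounds measured in an assay on isolated protein for activation of cGMP-dependent protein kinase 1 (Homo sapiens), read by ADP-Glo, with stated times of 30 min and 2 h (on this read-out higher numbers stand for an effect only at larger amounts of compound and lower numbers for an effect already at smaller amounts), at 144000 nM. Its nearest neighbour is compound 2 `O=C(O)c1ccc(CN2CCC[C@H](O[C@H](CO)c3cc(Cl)cc(Cl)c3)[C@@H]2c2ccccc2)cc1`, which in this assay gives 77000 nM; the gap a 1.9-fold higher number from compound 2 to compound 3 (0.27 log units; within the scatter) is within the scatter. Furthest away is compound 1 `O=C(O)c1ccc(CN2CCC[C@H](O[C@H](CO)c3cc(Cl)cc(Cl)c3)[C@@H]2c2ccccc2)c([N+](=O)[O-])c1`, which gives 13000 nM, so that an 11-fold higher number from compound 1 to compound 3 (1.04 log units; beyond the scatter) is large, and the step of a 5.9-fold higher number from compound 1 to compound 2 (0.77 log units; beyond the scatter) is modest.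

Compound 4 `OC[C@@H](O[C@H]1CCCN(Cc2nc3ccccc3[nH]2)[C@H]1c1ccccc1)c1cc(Cl)cc(Cl)c1` differs from compound 3 in one place: a group of 9 heavy atoms (7 carbon, 2 nitrogen; one five-membered aromatic ring with 2 hetero atoms, one six-membered aromatic ring of carbon only) in place of a group of 10 heavy atoms (7 carbon, 1 nitrogen, 2 oxygen; one six-membered aromatic ring with 1 hetero atom), on a saturated chain carbon bound to an amine nitrogen in a ring. Within the data shown here, two measured steps touch the same place on the shared core, the large one from compound 1 and the one from compound 2 that lies within the scatter, but neither brings in a group like the one entering here, so they set no direction for the new change. The account therefore expects a step of a 1.0-fold higher number from compound 3 to compound 4 (0.02 log units; within the scatter) that stays close to the scatter, with wide uncertainty. The estimate for compound 4 in this assay is 150000 nM, within a range from 40000 nM to 600000 nM.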

Compound 4, half-maximal effective concentration: > 200000 nM
Compound 4: a limit, no number; the forecaster's own chance of this, stated with the estimate: 25%; middle value at least 1.3-fold (0.12 log units) from the limit.
By their numbers in this assay, from the lowest: compound 1; then compounds 2 and 3 (each within the scatter of the next). At a limit, above all of these: compound 4.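

In this assay compound 4 gives a limit and not a number: the limit of > 200000 nM in this assay, at which 1 of the 4 values shown sits.

At this position, on a saturated chain carbon bound to an amine nitrogen in a ring, 1H-benzimidazol-2-yl is the only group shown without a carboxylic acid, and it gives an at least 2.5-fold higher number from compound 2 to compound 4 (0.41 log units; beyond the scatter) and an at least 15-fold higher number from compound 1 to compound 4 (1.18 log units; beyond the scatter). The remaining step, an at least 1.3-fold higher number from compound 3 to compound 4 (0.14 log units; that floor lies within the scatter), has a floor within the scatter, so the change is shown to matter only against the two benzene-ring acids and not against the pyridine-ring acid.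

On these data alone, how far past its limit compound 4 lies stays open, and with it the true size of all three steps. Also open, as far as these compounds go, is whether a carboxylic acid set on the 1H-benzimidazol-2-yl group, or an amine in its place, would lower the number.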